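Solubility notes on a pyrazole acylsulfonamide series

The compounds below may be only part of what the source reports. "The series", "measured", "known", "first", "only" and "open" are said of these compounds alone.

Measured compounds:
- compound 1 `CS(=O)(=O)NC(=O)CCc1cn(-c2ccc(Br)cc2)nc1-c1ccc(Cl)cc1`: 170000 nM
- compound 2 `CS(=O)(=O)NC(=O)CCc1cn(-c2ccc(Br)cc2)nc1-c1ccncc1`: 185000 nM
- compound 3 `CS(=O)(=O)NC(=O)NCc1cn(-c2ccc(Cl)cc2)nc1-c1ccncc1`: 150000 nM

All three values come from a physicochemical assay for solubility, in phosphate buffer, measured as thermodynamic solubility, at pH 7.4; on this read-out higher numbers stand for higher solubility and lower numbers for lower solubility. The step of a 1.1-fold lower number from compound 2 to compound 1 (0.04 log units; within the scatter) is the measured instance of the change (4-chlorophenyl in place of pyridin-4-yl on an aromatic carbon). Compound 3 and compound 2 differ in more than one place; the difference between the two cores is not broken down here.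

Compound 4 `CS(=O)(=O)NC(=O)NCc1cn(-c2ccc(Cl)cc2)nc1-c1ccc(Cl)cc1` is not yet measured in this assay. It arises from compound 3 by 4-chlorophenyl in place of pyridin-4-yl on an aromatic carbon, the same kind of change as from compound 2 to compound 1, though the place lines differ: the ring atom two bonds away bears a 4-chlorophenyl group rather than a 4-bromophenyl group, and the neighbouring ring atom carries a (((methylsulfonyl)carbamoyl)amino)methyl group rather than a 2-((methylsulfonyl)carbamoyl)ethyl group.

Because compound 3 gives 150000 nM and the earlier step was a 1.1-fold lower number from compound 2 to compound 1 (0.04 log units; within the scatter), a step of about a 1.2-fold lower number from compound 3 to compound 4 (0.06 log units; within the scatter) is expected. Compound 4 is therefore estimated at 130000 nM, most likely between 60000 nM and 280000 nM.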

Compound 4, solubility: < 5000 nM
Compound 4: no number, only a limit; the forecaster's own chance of this, stated with the estimate: 5%; middle value at least 26-fold (1.41 log units) from the limit.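

In this assay the exchange of pyridin-4-yl for 4-chlorophenyl gives a 1.1-fold lower number from compound 2 to compound 1 (0.04 log units; within the scatter) on one core but an at least 30-fold lower number from compound 3 to compound 4 (1.47 log units; beyond the scatter) on the other, so the size of the step did not carry over between these two cores. Compound 4 gives < 5000 nM, which is a limit and not a number. The two pairs differ both in the (((methylsulfonyl)carbamoyl)amino)methyl or 2-((methylsulfonyl)carbamoyl)ethyl chain and in the 4-chlorophenyl or 4-bromophenyl group, and the data do not show which of these differences goes with the larger step, nor what underlies it.

The compounds shown leave open how each of those two differences acts alone. Also open, as far as these compounds go, is whether the same exchange would give a large step on a core carrying a carboxylic acid or an amine in that chain.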